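Swapping the Benzyl Substituent from Compound 2 to Compound 4

The compounds below may be only part of what the source reports. "The series", "measured", "known", "first", "only" and "open" are said of these compounds alone.

Of the compounds shown here, three built on one shared core have so far been tested in a functional assay on NCI-H460 cells (Homo sapiens) for inhibition, read by sulforhodamine B assay, with a stated time of 48 h; a higher number here means that more compound is tolerated, a lower number that less compound is tolerated. Compound 1 `CCOC(=O)[C@H](CCC(=O)O)NC(=O)c1ccc(CNc2nc3cc(N)cc(N)c3nc2-c2ccccc2)cc1` carries an acid-bearing side chain joined to the core through an amide; in this assay compound 1 gives < 100000 nM, which is a limit of the assay rather than a number. Compound 3 `CCOC(=O)[C@H](CCC(=O)O)NC(=O)c1ccc(Sc2nc3cc(N)cc(N)c3nc2-c2ccccc2)cc1` keeps that side chain with a different link to the core; in this assay compound 3 gives < 100000 nM, again a limit. Compound 2 `Nc1cc(N)c2nc(-c3ccccc3)c(NCc3ccc(Cl)c(Cl)c3)nc2c1` is the simplest of the three, carrying a 3,4-dichlorobenzyl group; in this assay compound 2 gives < 100000 nM, once more only a limit. Compound 2 therefore stands at the same limit as the other two, and no order among them can be read, because the limit of < 100000 nM in this assay, at which 3 of the 3 values shown sit, is all that is known.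

Compound 4 `COc1ccc(CNc2nc3cc(N)cc(N)c3nc2-c2ccccc2)cc1` differs from compound 2 in one place: 4-methoxyphenyl in place of 3,4-dichlorophenyl on a saturated chain carbon bound to a nitrogen on an aromatic ring. Among the compounds with values here, no step between two measured compounds is known here, so there is no measured guide for how large a change this swap brings. For compound 4 the expected step is a step that the limit leaves unreadable from compound 2 to compound 4, which is not expected to stand out beyond the scatter. The estimate for compound 4 in this assay is 30000 nM, within a range from 5000 nM to 100000 nM, most likely reported again only as a limit.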

Compound 4, concentration lethal to 50% of the cells: < 100000 nM
Compound 4: no number, only a limit; the forecaster's own chance of this, stated with the estimate: 60%; the middle value is on the limit's open side.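

The swap of 3,4-dichlorobenzyl to 4-methoxybenzyl gives no readable step between compound 2 and compound 4, because both values are limits and not numbers: the limit of < 100000 nM in this assay, at which 4 of the 4 values shown sit. The compounds shown leave open how far each one lies from that limit, and whether this swap changes the result at all.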